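This account rests on a few compounds, and the source may have more. Where it says the series, first, only, none or still open, it means among the compounds named here.

Measured compounds:
- compound 1 `CCN(Cc1cccs1)C(=O)COc1ccc(F)cc1`: 422 nM
- compound 2 `C=CCN(Cc1cccs1)C(=O)COc1ccc(C)cc1`: 20 nM
- compound 3 `Cc1ccc(OCC(=O)N(Cc2cccs2)c2ccccn2)cc1`: 200 nM

In an assay on HEK293 cells for agonist activity at transient receptor potential cation channel subfamily M member 8 (Homo sapiens), read by fluorescence and calcium flux, with a stated time of 15 min (on this read-out lower numbers stand for an effect already at smaller amounts and higher numbers for an effect only at larger amounts of compound), compound 1 gives 422 nM, the highest of the three numbers; compound 3 gives 200 nM and compound 2 gives 20 nM, both lower than compound 1 beyond the scatter. Among the compounds with values here, the one step measured, a 10-fold higher number from compound 2 to compound 3 (1.00 log units; beyond the scatter), concerns the group on the amide-type nitrogen and does not touch the aromatic ring of the aryl ether part. Compound 4 `CCN(Cc1cccs1)C(=O)COc1ccccc1` differs from compound 1 in hydrogen in place of fluoro on an aromatic carbon. Within the data shown here, no measured pair isolates this change: compound 1 and compound 2 differ at the ring and also at the nitrogen, so their values show only that the two changes together give a lower number. For compound 4 the expected step is therefore small, most likely within the scatter, with a slight lean toward a higher number because compound 1, at 422 nM, already sits at the weak end. Compound 4 is estimated at 550 nM, range 200 nM to 1600 nM, a step of a 1.3-fold higher number from compound 1 to compound 4 (0.12 log units; within the scatter) that is expected to stay near the scatter.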

Compound 4, half-maximal effective concentration: 1400 nM
Estimate against measurement, compound 4: 2.5-fold (0.41 log units) below; measured number inside the range.
By their numbers in this assay, from the lowest: compound 2; then compound 3; then compound 1; then compound 4.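

In this assay, within the data shown here, hydrogen in place of fluoro on an aromatic carbon, para to a large group, gives a 3.3-fold higher number from compound 1 to compound 4 (0.52 log units; beyond the scatter) as the only step measured at this position. Compound 1 and compound 2 differ at the ring and also at the nitrogen, so neither change could be read alone from them, whereas this pair leaves the group on the nitrogen untouched. The ring position therefore moves the number by itself, and the series now has a step beyond the scatter at the ring as well as a 10-fold higher number from compound 2 to compound 3 (1.00 log units; beyond the scatter) at the nitrogen.

Going by these compounds, how methyl compares with fluoro or hydrogen on an unchanged ethyl nitrogen stays open, as does how a methoxy or chloro group would read at this place. Nothing in hand gives a reason for the step.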